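Shortening an alkyl group on a shared core

A few compounds are considered here, and "the series" means these few. Any claim that something is new, unique, unknown or untested is made for them only; others in the source may bear on it.

Measured so far:
Compound 1, `C=C(OCC)c1ccc(Nc2cccc3c2C(=O)N(C2CCC(=O)NC2=O)C3=O)cc1`, gives 10% in an assay on FRT-Jurkat cells for inhibition of nuclear factor NF-kappa-B complex (Homo sapiens), read by flow cytometry, with a stated time of 24 h, tested at 10 uM; a higher number here means more inhibition at the concentration tested (going by the name of the read-out), a lower number less inhibition.
Compound 2, `CC(C)(C)c1ccc(Nc2cccc3c2C(=O)N(C2CCC(=O)NC2=O)C3=O)cc1`, gives 36% in this assay.

Going by the values given here, compound 2 stands at the higher of the two numbers in this assay; its nearest neighbour is compound 1, and the one step known, a number 26 percentage points higher from compound 1 to compound 2 (beyond the scatter), lies beyond the scatter. Compound 3, `CCc1ccc(Nc2cccc3c2C(=O)N(C2CCC(=O)NC2=O)C3=O)cc1`, is not yet measured. It differs from compound 2 in one place: ethyl in place of tert-butyl on an aromatic carbon. No measured step involves this exact change; the only step shown swaps a 1-ethoxyethenyl for a tert-butyl on the same aromatic carbon, so it bears on the place of the change but not on its nature. Compound 3 is therefore expected to sit somewhat below compound 2 in this assay, by a step of about a number 11 percentage points lower from compound 2 to compound 3 (beyond the scatter), though a number within the scatter of compound 2 would not surprise. The estimate for compound 3 in this assay is 25%, with a range from 5% to 45%.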

Compound 3, a percentage reported as inhibition, at one concentration (the size of the read-out at that concentration, not a potency): 17%
Beside the measured number, compound 3's estimate is 8 percentage points above it; the range from low to high includes it.
By their numbers in this assay, from the lowest: compounds 1 and 3 (each within the scatter of the next); then compound 2.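

The earlier pair showed only that this aromatic carbon matters when a 1-ethoxyethenyl group gives way to tert-butyl; compound 3 shows that in this assay the read-out also responds to a change between two plain alkyl groups, with the move from the 4-(tert-butyl)phenyl to the 4-ethylphenyl group giving a number 19 percentage points lower from compound 2 to compound 3 (beyond the scatter). The other new comparison gives a number 7 percentage points higher from compound 1 to compound 3 (within the scatter), so the ethyl and 1-ethoxyethenyl groups cannot be told apart here, and among these three compounds only the tert-butyl group stands clear of the other two. Nothing available accounts for this difference between the groups.

Going by these compounds, whether the number climbs steadily from ethyl to tert-butyl or depends on something particular to the tert-butyl group remains open, and an isopropyl group or a longer chain such as n-butyl on the same aromatic carbon would bear on that question. The compounds shown also leave open how a group of a different kind at this place, such as an amine or a carboxylic acid, would read in this assay.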